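A few compounds are considered here, and "the series" means these few. Any claim that something is new, unique, unknown or untested is made for them only; others in the source may bear on it.

Among the compounds with values here, compound 2 `CCc1cc(-c2nc(-c3cc(C)c(OC[C@@H](O)CNC(=O)CO)c(CC)c3)no2)ccc1CN(C)C` is the compound with the only number given in an ADME assay on liver (strain Wistar) for metabolic stability, with Liver microsome (Rattus norvegicus) as the target, read by LC-MS, using microsomes and NADPH, with a stated time of 15 min, tested at 1 uM; on this read-out higher numbers stand for fast clearance and lower numbers for slow clearance: in this assay compound 2 gives 9200 mL.min-1.g-1. Compound 1 `CCc1cc(-c2noc(-c3cc(C)cc(CN(C)CC)c3)n2)cc(C)c1OC[C@@H](O)CNC(=O)CO` in this assay gives only a limit, > 5000 mL.min-1.g-1. The step that the limit leaves unreadable from compound 1 to compound 2 therefore cannot be sized, because of the limit of > 5000 mL.min-1.g-1 in this assay, at which 1 of the 2 values shown sits. Compound 3 `CCc1cc(-c2noc(-c3cc(C)c(CN(C)C)s3)n2)cc(C)c1OC[C@@H](O)CNC(=O)CO` differs from compound 2 by 5-((dimethylamino)methyl)-4-methylthiophen-2-yl in place of 4-((dimethylamino)methyl)-3-ethylphenyl on an aromatic carbon. No readable measured step bears on this change, so the expected step of a 1.2-fold lower number from compound 2 to compound 3 (0.06 log units; within the scatter) in this assay is judged small, not beyond the usual scatter. Compound 3 is expected to give 8000 mL.min-1.g-1 in this assay, with a range from 3000 mL.min-1.g-1 to 20000 mL.min-1.g-1.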

Compound 3, intrinsic clearance in microsomes: 8100 mL.min-1.g-1
Compound 3: middle estimate off by 1.0-fold (0.01 log units), on the low side; low and high end bracket the measured number.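

In this assay, within the data shown here, the swap of 4-((dimethylamino)methyl)-3-ethylphenyl for 5-((dimethylamino)methyl)-4-methylthiophen-2-yl gives the first readable step at this position: a 1.1-fold lower number from compound 2 to compound 3 (0.06 log units; within the scatter). Exchanging the six-membered aromatic ring of carbon only for the five-membered one with 1 hetero atom therefore leaves no difference that stands out from the scatter. Compound 1 gives only a limit, so the steps from it cannot be read: the limit of > 5000 mL.min-1.g-1 in this assay, at which 1 of the 3 values shown sits.

The compounds shown leave open whether a morpholine or a carboxylic acid in place of the dimethylamino group would give a number apart from these.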